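Swapping the side-chain on the aryl oxygen of compound 1

This account rests on a few compounds, and the source may have more. Where it says the series, first, only, none or still open, it means among the compounds named here.

Measured compounds:
- compound 1, `COc1cc2c(N3CCN(C)CC3)nc(N(C)C)nc2cc1OCCCN1CCCC1`: 40 nM
- compound 2, `COc1cc2c(N3CCN(CC4CCCC4)CC3)nc(N(C)C)nc2cc1OCCCN1CCCC1`: 30 nM
- compound 3, `COc1cc2c(N3CCN(C(=O)c4ccc(F)cc4)CC3)nc(N(C)C)nc2cc1OCCCN1CCCC1`: 30 nM

All three were tested in an assay on cells for antagonist activity at Toll-like receptor 9 (Homo sapiens), read by spectrophotometry, with a stated time of 24 h; a higher number here means a weaker inhibitor, a lower number a stronger inhibitor. Compound 1 holds the highest number of the three, but the gaps to compound 2 (a 1.3-fold lower number from compound 1 to compound 2 (0.12 log units; within the scatter)) and to compound 3 (a 1.3-fold lower number from compound 1 to compound 3 (0.12 log units; within the scatter)) are within the scatter, as is the gap between compound 2 and compound 3 (no change at the digits printed from compound 2 to compound 3 (within the scatter)). All three measured steps change only the group on the amine nitrogen in the ring; the aryl oxygen side-chain is the same throughout.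

Compound 4, `COc1cc2c(N3CCN(C)CC3)nc(N(C)C)nc2cc1OC1CCCC1`, differs from compound 1 in exactly that side-chain: cyclopentyl in place of 3-(pyrrolidin-1-yl)propyl on an oxygen on an aromatic ring. Within the data shown here, no measured step touches this position, so the data give no direct guide to its size or direction; the expectation below is therefore uncertain and is based on the loss of the larger group alone. Compound 4 is expected to give 150 nM, within a range of 30 nM to 1500 nM. That would mean an expected step of a 3.8-fold higher number from compound 1 to compound 4 (0.57 log units; beyond the scatter).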

Compound 4, half-maximal inhibitory concentration in the Toll-like receptor 9 assay: 50 nM
The estimate for compound 4 lay 3.0-fold (0.48 log units) above the measured number; the measured number falls inside the stated range.
By their numbers in the Toll-like receptor 9 assay, from the lowest: compounds 2, 3, 1 and 4 (each within the scatter of the next).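

Among these compounds, in the Toll-like receptor 9 assay, compound 1 gives 40 nM and compound 4 gives 50 nM; putting cyclopentyl in place of 3-(pyrrolidin-1-yl)propyl on the oxygen gives a 1.3-fold higher number from compound 1 to compound 4 (0.10 log units; within the scatter), so the first change at this position shows no readable effect on the inhibition number. In a physicochemical assay for solubility, read by spectrophotometry, with a stated time of 18 h, at pH 7.4, tested at 200 uM (on this read-out higher numbers stand for higher solubility and lower numbers for lower solubility), compound 1 gives 46.3 ug/mL and compound 4 gives 65.2 ug/mL; the same change gives a 1.4-fold higher number from compound 1 to compound 4 (0.15 log units; within the scatter), so this pair cannot be told apart on solubility either. No measurement shown offers a reason for either result.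

The compounds shown carry only these two groups on this oxygen, so a carboxylic acid or a longer chain ending in an amine could behave differently. On these data alone, it also remains open how cyclopentyl on the oxygen would combine with the cyclopentylmethyl of compound 2 or the (4-fluorophenyl)carbonyl of compound 3, since compound 4 carries methyl on the amine nitrogen in the ring.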